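The source may report more compounds than this note shows. Statements on the series, on what has been measured and on what is new or still open speak of the compounds shown alone.

Among the compounds with values here, compound 2 `C/C(=N\NC(=O)c1cccc(S(=O)(=O)N2CCOCC2)c1)c1ccc(O)cc1` is the weaker of the two compounds measured so far: in a functional assay on EC9706 cells (Homo sapiens) for antiproliferative activity, read by MTT assay, with a stated time of 72 h (a lower number here means a stronger inhibitor, a higher number a weaker inhibitor), compound 2 gives 71400 nM, the highest of the two numbers. Its nearest neighbour is compound 1 `C/C(=N\NC(=O)c1cccc(S(=O)(=O)N2CCOCC2)c1)c1ccccc1O`, which in this assay gives 1220 nM; the two differ only in the hydroxyphenyl group, and a 59-fold higher number from compound 1 to compound 2 (1.77 log units; beyond the scatter). Compound 3 `C/C(=N\NC(=O)c1cccc(S(=O)(=O)N2CCOCC2)c1)c1cccc(N)c1O` has not yet been measured. Compared with compound 2 it carries a (3-amino-2-hydroxyphenyl in place of 4-hydroxyphenyl on a carbon with a double bond to nitrogen). Within the data shown here, the one step that bears on this change is the one from compound 1 to compound 2, where exchanging 2-hydroxyphenyl for 4-hydroxyphenyl raised the number by a large margin, well beyond the scatter. Among the measured compounds shown here, compound 3 returns to a 2-hydroxyphenyl pattern, now with an added amino group, so a large step back down, towards the number of compound 1, is expected, tempered by the fact that no measured compound shows the effect of the amino group on its own. For compound 3 the expected step in this assay is a 48-fold lower number from compound 2 to compound 3 (1.68 log units; beyond the scatter), giving an estimated value of 1500 nM, with a range from 300 nM to 8000 nM.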

Compound 3, half-maximal inhibitory concentration: 3520 nM
Compound 3: middle estimate off by 2.3-fold (0.37 log units), on the low side; low and high end bracket the measured number.
By their numbers in this assay, from the lowest: compound 1; then compound 3; then compound 2.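

In this assay, the 3-amino-2-hydroxyphenyl group on the carbon with a double bond to nitrogen recovers most of what the 4-hydroxyphenyl group lost, with a 20-fold lower number from compound 2 to compound 3 (1.31 log units; beyond the scatter), so a low number at this position is not confined to the plain 2-hydroxyphenyl group of compound 1. The amino group can now be read on its own: amino in place of hydrogen on an aromatic carbon gives a 2.9-fold higher number from compound 1 to compound 3 (0.46 log units; beyond the scatter), a modest step that is beyond the scatter yet much smaller than a 59-fold higher number from compound 1 to compound 2 (1.77 log units; beyond the scatter). Among these three compounds, both that carry a 2-hydroxyphenyl pattern give lower numbers than compound 2, and none goes against this, so here the hydroxyl pattern counts for more than the added amino group.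

Nothing available here explains why these numbers differ. Going by these compounds, it remains open whether a methoxy group, a fluorine atom or a methyl group in place of the amino group would give a similar rise from compound 1, and whether amino added to the 4-hydroxyphenyl group of compound 2 would change its number at all.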